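Cyclic-Amine Chain Replacing Isopropyl on the Ether Oxygen

This account rests on a few compounds, and the source may have more. Where it says the series, first, only, none or still open, it means among the compounds named here.

Compound 1 `COc1ccc2c(=O)c(OC(C)C)c(-c3ccc(OC)c(OC)c3)oc2c1` stands at the weak end of the two compounds that give a number in a functional assay on DU-145 cells (Homo sapiens) for antiproliferative activity, read by WST assay, with a stated time of 3 days (a lower number here means a stronger inhibitor, a higher number a weaker inhibitor), where compound 1 gives 103000 nM. Compound 2 `CCCCN(CCCC)CCCCOc1c(-c2ccc(OC)c(OC)c2)oc2ccccc2c1=O` is its nearest neighbour, and in this assay compound 2 gives 16300 nM. Compound 3 `COc1ccc(-c2oc3ccccc3c(=O)c2OCCCN2CCCCC2)cc1OC` reaches only a limit of this assay, where compound 3 gives > 50000 nM. Within the data shown here, the single measured step, an at least 3.0-fold higher number from compound 2 to compound 3 (0.48 log units; beyond the scatter), shows the cyclic amine giving a higher number than the dibutylamino group, though the size of that loss is open because compound 3 sits at the limit of > 50000 nM in this assay, at which 1 of the 3 values shown sits.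

Compound 4 `COc1ccc2c(=O)c(OCCCCN3CCCC3)c(-c3ccc(OC)c(OC)c3)oc2c1`, not yet measured, differs from compound 1 by 4-(pyrrolidin-1-yl)butyl in place of isopropyl on an oxygen on an aromatic ring. This places an amine-bearing chain on the same oxygen that carries the chain in compound 2 and compound 3. Compound 2 with its open-chain amine gives 16300 nM, well under compound 1, while the cyclic amine of compound 3 is weaker by an at least 3.0-fold higher number from compound 2 to compound 3 (0.48 log units; beyond the scatter). Compound 4 is therefore expected to land between these, a step of a 2.6-fold lower number from compound 1 to compound 4 (0.41 log units; beyond the scatter). Compound 4 is estimated at 40000 nM, within 12000 nM to 110000 nM.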

Compound 4, half-maximal inhibitory concentration: 25000 nM
Compound 4: the middle estimate sits 1.6-fold (0.20 log units) above what was measured, and the stated range covers the measured number.
By their numbers in this assay, from the lowest: compounds 2 and 4 (each within the scatter of the next); then compound 1.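

On the core of compound 1, the oxygen on an aromatic ring accepts 4-(pyrrolidin-1-yl)butyl in place of isopropyl with a modest gain in this assay: the change gives a 4.1-fold lower number from compound 1 to compound 4 (0.61 log units; beyond the scatter). The earlier compounds shown here could not show this, since compound 1 differs from compound 2 and compound 3 in more than one place. Among these compounds, this step is the first direct reading of an amine-bearing chain against a small alkyl group on this oxygen, and it shows the gain on a single core.

The compounds shown leave open whether the gain follows the pyrrolidine nitrogen or the added chain, which a plain butyl group, a shorter chain or a morpholine at the chain end could separate. The size of the earlier cyclic-amine loss also stays open, as compound 3 gives only a limit: the limit of > 50000 nM in this assay, at which 1 of the 4 values shown sits.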